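Diethylamino Added to the Core of Compound 1

The source may hold more compounds than are shown below. What is called first, only, known or untested is meant among the compounds shown, and "the series" means these compounds.

Compound 1 `O=C(/C=C/c1ccc([N+](=O)[O-])o1)c1ccccc1` is the parent of this small set. In a toxicity assay on Vero cells (Chlorocebus sabaeus) for cytotoxicity (a higher number here means that more compound is tolerated, a lower number that less compound is tolerated), compound 1 gives 444000 nM, the highest of the three numbers shown, although the gaps to its neighbours are within the scatter: compound 3 `O=C(/C=C/c1ccc([N+](=O)[O-])o1)c1ccc(OCc2ccc(OC(F)(F)F)cc2)cc1` gives 335000 nM and compound 2 `O=C(/C=C/c1ccc([N+](=O)[O-])o1)c1ccc(OCc2cccc(Cl)c2)cc1` gives 307000 nM. Within the data shown here, the one step that changes a single place is a 1.4-fold lower number from compound 1 to compound 2 (0.16 log units; within the scatter).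

Compound 4 `CCN(CC)c1ccc(C(=O)/C=C/c2ccc([N+](=O)[O-])o2)cc1` differs from compound 1 in one place: diethylamino in place of hydrogen on an aromatic carbon. Among the measured compounds shown here, no measured step introduces this group, so the nearest guide is the step from compound 1 to compound 2, which put a large group on an aromatic carbon of the same ring and left the number within the scatter, and the value of compound 3 shows the same picture. The expected step is a 1.1-fold lower number from compound 1 to compound 4 (0.05 log units; within the scatter), that is, nothing beyond the scatter in this assay. Compound 4 is estimated at 400000 nM in this assay, with a range from 200000 nM to 800000 nM.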

Compound 4, half-maximal cytotoxic concentration: 334000 nM
Compound 4: middle estimate off by 1.2-fold (0.08 log units), on the high side; low and high end bracket the measured number.
By their numbers in this assay, from the lowest: compounds 2, 4, 3 and 1 (each within the scatter of the next).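

In this assay the step of a 1.3-fold lower number from compound 1 to compound 4 (0.12 log units; within the scatter) shows that this aromatic carbon, para to a large group, takes diethylamino, a group with nitrogen and no ring, and the number stays within the scatter. The earlier compounds shown here showed this only for ring-bearing groups, and the exchange of one kind for the other, a 1.1-fold higher number from compound 2 to compound 4 (0.04 log units; within the scatter), also stays within the scatter, so across compounds 1, 2 and 4 neither the size of the group nor the presence of its ring shows any readable effect on the number. No measurement shown here accounts for this lack of change.

Going by these compounds, whether a carboxylic acid or a primary amine at this carbon would also stay within the scatter remains open. So does the effect of diethylamino on another carbon of the same ring.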